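Three Compounds at the Limit, a Fourth to Come

This account rests on a few compounds, and the source may have more. Where it says the series, first, only, none or still open, it means among the compounds named here.

Of the compounds shown here, three that share a core have been tested in a functional assay on Daoy cells (Homo sapiens) for cytotoxicity, read by MTT assay, with a stated time of 72 h; a lower number here means a stronger inhibitor, a higher number a weaker inhibitor. Compound 1 `COc1ccc(N(C)C(=O)N(C)c2cc(OC)c(OC)c(OC)c2)cc1` carries a 4-methoxyphenyl group on one amide-type nitrogen. In this assay compound 1 gives >= 125000 nM, which is a limit of the assay and not a number. Compound 2 `COc1cc(N(C)C(=O)N(C)c2cccc([N+](=O)[O-])c2)cc(OC)c1OC` bears a 3-nitrophenyl group in that place; in this assay compound 2 gives >= 125000 nM, again a limit rather than a number. Compound 3 `COc1cc(N(C)C(=O)N(C)c2ccc([N+](=O)[O-])cc2)cc(OC)c1OC` carries a 4-nitrophenyl group, and in this assay compound 3 gives >= 125000 nM, also a limit. Because all three values sit at the same limit (the limit of >= 125000 nM in this assay, at which 3 of the 3 values shown sit), the steps a step that the two limits leave unreadable from compound 1 to compound 2, a step that the two limits leave unreadable from compound 1 to compound 3 and a step that the two limits leave unreadable from compound 2 to compound 3 have no readable size. Compound 3 thus stands exactly where compounds 1 and 2 stand, at the limit, with no order among them.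

Compound 4 `COc1cc(N(C)C(=O)N(C)c2cccc(F)c2)cc(OC)c1OC` differs from compound 3 by 3-fluorophenyl in place of 4-nitrophenyl on an amide-type nitrogen. For the measured compounds named here, no measured step touches an exchange of a nitro-bearing ring for a fluorine-bearing one, and the three steps that exist cannot be read. Going by the values given here, the only guide is that every change among the measured compounds left the value at the limit. The expected step is therefore a number no higher from compound 3 to compound 4 (the limit leaves the size open), none beyond the scatter. Compound 4 is estimated at 125000 nM, with a range from 40000 nM to 500000 nM, and most likely it too will be reported only as a limit.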

Compound 4, half-maximal inhibitory concentration: >= 125000 nM
Compound 4 was reported as a limit; the forecaster's own chance of this, stated with the estimate: 85%; the middle value sits exactly at the limit.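

Compound 4 gives >= 125000 nM in this assay and this is a limit of the assay, not a number. Its steps to compound 1, compound 2 and compound 3 cannot be read, since all four compounds sit at the same limit: the limit of >= 125000 nM in this assay, at which 4 of the 4 values shown sit. The compounds shown leave open which change on an amide-type nitrogen, if any, would give a readable number.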